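A few compounds are considered here, and "the series" means these few. Any claim that something is new, unique, unknown or untested is made for them only; others in the source may bear on it.

Compound 1 `COc1cccc(CNC(=O)c2nc(Br)c3cccnc3c2N[C@H]2CC[C@H](N)CC2)c1` gives 6000 nM in a functional assay on SK-BR-3 cells (Homo sapiens) for cytotoxicity, read by MTT assay, with a stated time of 72 h; a lower number here means a stronger inhibitor, a higher number a weaker inhibitor.
Compound 2 `Nc1ccc(Nc2c(C(=O)NCc3ccc(F)cc3)nc(Br)c3cccnc23)cc1` gives 4000 nM in this assay.
Compound 3 `COC(=O)CNc1c(C(=O)NCc2ccc(F)cc2)nc(Br)c2cccnc12` gives 1000 nM in this assay.

Among these three, compound 1 has the highest number in this assay; compound 2 lies within the scatter of it, while compound 3 lies beyond. Going by the values given here, the only measured single-point step, a 4.0-fold lower number from compound 2 to compound 3 (0.60 log units; beyond the scatter), changes the substituent on a nitrogen on an aromatic ring, not the amide-type nitrogen, so it does not bear directly on the change considered here.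

Compound 4 `N[C@H]1CC[C@H](Nc2c(C(=O)Nc3ccccc3)nc(Br)c3cccnc23)CC1` differs from compound 1 in phenyl in place of 3-methoxybenzyl on an amide-type nitrogen. Among the compounds with values here, with no measured step touching the amide-type nitrogen, the expectation is for no change beyond the scatter, that is a 1.2-fold lower number from compound 1 to compound 4 (0.08 log units; within the scatter), carrying wide uncertainty. Compound 4 is therefore estimated at 5000 nM, with a range from 1500 nM to 16000 nM.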

Compound 4, half-maximal inhibitory concentration: 2000 nM
Estimate against measurement, compound 4: 2.5-fold (0.40 log units) above; the range from low to high includes it.
By their numbers in this assay, from the lowest: compounds 3, 4, 2 and 1 (each within the scatter of the next, the first and the last beyond it).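

Going by these compounds alone, the amide-type nitrogen is not a silent place: phenyl in place of 3-methoxybenzyl gives a 3.0-fold lower number from compound 1 to compound 4 (0.48 log units; beyond the scatter) in this assay, the first measured step here. Because the whole 3-methoxybenzyl group leaves at once, this one step cannot separate the methoxy from the benzyl carbon. No measured evidence explains the step.

Open, going by these compounds, is whether plain benzyl or a longer chain such as phenethyl on this nitrogen would stand with compound 1 or compound 4. Also open, on these data alone, is what a methoxy or an amine on the phenyl of compound 4 would do.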